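This account rests on a few compounds, and the source may have more. Where it says the series, first, only, none or still open, it means among the compounds named here.

Measured compounds:
Compound 1 `NC(=S)N/N=C/c1ccc2ccccc2n1`, which in a functional assay on HeLa cells (Homo sapiens) for antiproliferative activity, read by sulforhodamine B assay, with a stated time of 72 h (a higher number here means a weaker inhibitor, a lower number a stronger inhibitor), gives 960 nM.
Compound 2 `S=C(N/N=C/c1ccc2ccccc2n1)Nc1ccc(Br)cc1`, which in this assay gives 56800 nM.
Compound 3 `Fc1cccc(NC(=S)N/N=C/c2ccc3ccccc3n2)c1`, which in this assay gives 70100 nM.

Compound 3 has the highest number of the three. Its gap to compound 2 is within the scatter, whereas a 73-fold higher number from compound 1 to compound 3 (1.86 log units; beyond the scatter) is large, as is a 59-fold higher number from compound 1 to compound 2 (1.77 log units; beyond the scatter). Compound 4 `S=C(N/N=C/c1ccc2ccccc2n1)Nc1cccc(Cl)c1` differs from compound 3 by chloro in place of fluoro on an aromatic carbon. Going by the values given here, the one measured step that bears on such an exchange of chloro for fluoro is a 1.2-fold higher number from compound 2 to compound 3 (0.09 log units; within the scatter), which lies within the scatter; the large steps concern adding a whole substituted phenyl group, not changing the halogen on it. Therefore for compound 4 a step of a 1.1-fold lower number from compound 3 to compound 4 (0.03 log units; within the scatter) is expected, none beyond the scatter. Compound 4 is estimated at 65000 nM, between 28000 nM and 150000 nM.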

Compound 4, half-maximal inhibitory concentration: 52500 nM
Estimate against measurement, compound 4: 1.2-fold (0.09 log units) above; measured number inside the range.
By their numbers in this assay, from the lowest: compound 1; then compounds 4, 2 and 3 (each within the scatter of the next).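

In this assay, replacing fluoro with chloro at this position leaves the number within the scatter (a 1.3-fold lower number from compound 3 to compound 4 (0.13 log units; within the scatter)). The 3-chlorophenyl and 4-bromophenyl compounds also cannot be separated (a 1.1-fold lower number from compound 2 to compound 4 (0.03 log units; within the scatter)), while the large gap from the unsubstituted nitrogen remains with chloro in place (a 55-fold higher number from compound 1 to compound 4 (1.74 log units; beyond the scatter)). Nothing available explains these results.

The compounds shown leave open whether an amine or a carboxylic acid on the phenyl ring would bring the number closer to that of compound 1. They also leave open whether a methyl group on that nitrogen would give a similarly large step.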